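The compounds below may be only part of what the source reports. "The series", "measured", "known", "first", "only" and "open" are said of these compounds alone.

Measured so far in a functional assay on HEK293 cells for agonist activity at D(4) dopamine receptor (Homo sapiens), read by FLIPR; a higher number here means a larger maximal response, a lower number a smaller maximal response:

compound 1 `Cc1cc(C)cc(NC(=O)CN2CCC(c3cccc[n+]3[O-])CC2)c1` — 76%
compound 2 `Cc1cccc(NC(=O)CN2CCC(c3ccc(O)cc3)CC2)c1` — 60%
compound 3 `COc1cccc(C(=O)NCN2CCC(c3cccc[n+]3[O-])CC2)c1C` — 51%

Compound 2 sits in the middle of the three numbers. Its value and that of compound 3 lie within the scatter of each other, so no order between the two can be read. Compound 1 lies beyond the scatter above compound 2, with a larger maximal response.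

Compound 4 `Cc1cccc(NC(=O)CN2CCC(c3ccccc3F)CC2)c1` is not yet measured. It differs from compound 2 in one place: 2-fluorophenyl in place of 4-hydroxyphenyl on a saturated ring carbon. Among the compounds with values here, no pair of measured compounds spans this exchange, so nothing in the present numbers shows how large such a step tends to be, and the expectation rests on the value of compound 2 alone.

The step of a number 5 percentage points lower from compound 2 to compound 4 (within the scatter) is expected to be small, within the scatter or at most slightly downward. Compound 4 is therefore expected to give about 55% in this assay, with a range from 35% to 75%.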

Compound 4, largest response reached (reported as efficacy), in percent of the reference or control that the assay uses: 57%
The estimate for compound 4 lay 2 percentage points below the measured number, within the range that was stated.
By their numbers in this assay, from the lowest: compounds 3, 4 and 2 (each within the scatter of the next); then compound 1.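

In this assay, 2-fluorophenyl in place of 4-hydroxyphenyl on a saturated ring carbon gives a number 3 percentage points lower from compound 2 to compound 4 (within the scatter), the first step read at this position. The hydrogen-bond donor and acceptor of 4-hydroxyphenyl are absent from 2-fluorophenyl, yet the maximal response of this pair stays within the scatter, a finding that applies to this pair alone. Nothing available bears on why the two compounds read alike.

Going by these compounds, this single exchange alters both the substituent and its ring position, so the separate contributions remain open; 4-fluorophenyl and 2-hydroxyphenyl would divide them. Also open, on these data alone, is whether the position tolerates groups of another kind, such as an aminophenyl, a carboxyphenyl or a cyclohexyl ring, in this assay.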